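This account rests on a few compounds, and the source may have more. Where it says the series, first, only, none or still open, it means among the compounds named here.

Of the compounds shown here, three with the same core have been measured in an assay on HeLa cells for inhibition of sphingosine-1-phosphate transporter SPNS2 (Mus musculus), read by LC-MS, tested at 2 uM; on this read-out higher numbers stand for more inhibition at the one concentration tested (going by the name of the read-out) and lower numbers for less inhibition. Compound 2 `CCCCCCCCCCc1ccc(-c2noc(CN3CCNCC3)n2)cc1` gives 19%, the lowest of the three numbers. Compound 1 `CCCCCCCCCCc1ccc(-c2noc([C@@H]3CCCN3)n2)cc1` gives 21%, and the step of a number 2 percentage points lower from compound 1 to compound 2 (within the scatter) lies within the scatter. Compound 3 `CCCCCCCCCCc1ccc(-c2noc([C@@H](N)CCCCN)n2)cc1` gives 43%, and the step of a number 24 percentage points higher from compound 2 to compound 3 (beyond the scatter) is a modest gain beyond the scatter.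

Compound 4 `CCCCCCCCCCc1ccc(-c2noc([C@H](CCCCN)NC(C)=O)n2)cc1` differs from compound 2 by 1-acetamido-5-aminopentyl in place of (piperazin-1-yl)methyl on an aromatic carbon. For the measured compounds named here, only the step from compound 2 to compound 3 bears on this change, since compound 4 carries the same 5-aminopentyl chain while the second amine is replaced by an acetamido group, for which no measured step exists. A rise smaller than a number 24 percentage points higher from compound 2 to compound 3 (beyond the scatter) is therefore expected, namely a number 11 percentage points higher from compound 2 to compound 4 (beyond the scatter). Compound 4 is estimated at 30%, within a range from 14% to 48%.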

Compound 4, a percentage reported as inhibition, at one concentration (the size of the read-out at that concentration, not a potency): 40%
The estimate for compound 4 lay 10 percentage points below the measured number; the measured number falls inside the stated range.
By their numbers in this assay, from the lowest: compounds 2 and 1 (each within the scatter of the next); then compounds 4 and 3 (each within the scatter of the next).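

In this assay, acetyl in place of hydrogen on an amine nitrogen gives a number 3 percentage points lower from compound 3 to compound 4 (within the scatter), so that amine need not stay free for the number to hold. The 1-acetamido-5-aminopentyl group also keeps the gain over the ring-bearing groups, with a number 21 percentage points higher from compound 2 to compound 4 (beyond the scatter) and a number 19 percentage points higher from compound 1 to compound 4 (beyond the scatter). No supporting measurement is available to explain these steps.

Going by these compounds, whether the amine at the far end of the chain matters remains open. A hydroxyl or carboxylic acid there, or a shorter or longer chain, could answer that.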